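The source may hold more compounds than are shown below. What is called first, only, known or untested is meant among the compounds shown, and "the series" means these compounds.

Measured compounds:
- compound 1, `CC(C)CC(=O)Oc1ccc2oc(/C=C/[S+](C)[O-])cc(=O)c2c1`: 6100 nM
- compound 2, `COc1cccc2oc(/C=C/[S+](C)[O-])cc(=O)c12`: > 10000 nM, which is a limit of the assay and not a number

Among the compounds with values here, in a functional assay on DLD-1 cells (Homo sapiens) for cytotoxicity, with a stated time of 48 h (on this read-out lower numbers stand for stronger inhibition and higher numbers for weaker inhibition), compound 1 gives the only number, 6100 nM. Within the data shown here, for compound 2 this assay reports only (the limit of > 10000 nM in this assay, at which 1 of the 2 values shown sits), so no step between the two measured compounds can be put in figures, and the pair shows nothing beyond that compound 1 sits where a number could be read.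

The unmeasured compound 3, `CC(C)Oc1ccc2oc(/C=C/[S+](C)[O-])cc(=O)c2c1`, differs from compound 1 in one place: isopropyl in place of isobutylcarbonyl on an oxygen on an aromatic ring. Among the measured compounds shown here, no measured pair follows a change of this kind, so the size of the step has to be guessed. The expected step is a 1.3-fold higher number from compound 1 to compound 3 (0.12 log units; within the scatter), that is, none beyond the usual scatter, with the direction left open. Compound 3 is therefore expected to give about 8000 nM. The estimate for compound 3 spans from 3000 nM to 20000 nM.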

Compound 3, half-maximal inhibitory concentration: 8000 nM
Estimate against measurement, compound 3: no gap at the digits printed; the range from low to high includes it.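

In this assay, within the data shown here, isopropyl in place of isobutylcarbonyl on an oxygen on an aromatic ring gives a 1.3-fold higher number from compound 1 to compound 3 (0.12 log units; within the scatter), the first step that can be put in figures. At this position, 6 heavy atoms including the carbonyl leave and 3 carbon atoms enter, yet the two compounds stay within the usual scatter of each other, so the carbonyl is not needed to keep a readable number here. Steps involving compound 2 cannot be read.

Going by these compounds, whether an amine, a carboxylic acid or a longer carbon chain on this oxygen would move the number beyond the scatter remains open. The value for compound 2 remains a limit of the assay and not a number: the limit of > 10000 nM in this assay, at which 1 of the 3 values shown sits.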